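The source may report more compounds than this note shows. Statements on the series, on what has been measured and on what is new or still open speak of the compounds shown alone.

Compound 1, `COC(=O)/C=C/c1ccc2c(c1)C(=O)C(=O)N2Cc1cc(C)cc(C)c1`: 150 nM
Compound 2, `COc1ccc(CN2C(=O)C(=O)c3cc(/C=C/C(=O)N4CCCC4)ccc32)cc1`: 7810 nM
Compound 3, `COC(=O)/C=C/c1cccc2c1C(=O)C(=O)N2Cc1ccc(OC)cc1`: 5490 nM

In a functional assay on HepG2 cells (Homo sapiens) for cytotoxicity, read by MTT assay, with a stated time of 48 h (a higher number here means a weaker inhibitor, a lower number a stronger inhibitor), compound 1 gives the lowest number of the three measured compounds. Compound 3 sits far higher and compound 2 higher still, both gaps well beyond the usual scatter; each of these two compounds differs from compound 1 in more than one place, so no single change can be read from them.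

Compound 4, `COC(=O)/C=C/c1ccc2c(c1)C(=O)C(=O)N2Cc1ccccc1`, differs from compound 1 in one place: phenyl in place of 3,5-dimethylphenyl on a saturated chain carbon bound to an amide-type nitrogen in a ring. For the measured compounds named here, no measured pair shows this change alone, so its effect is not known from the data. The step of a 2.7-fold higher number from compound 1 to compound 4 (0.43 log units; beyond the scatter) is expected to be a modest rise, at or a little beyond the scatter. Compound 4 is thus estimated at 400 nM, within 100 nM to 2000 nM.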

Compound 4, half-maximal inhibitory concentration: 40 nM
Beside the measured number, compound 4's estimate is 10-fold (1.00 log units) above it; measured number outside the range, below it.
By their numbers in this assay, from the lowest: compound 4; then compound 1; then compounds 3 and 2 (each within the scatter of the next).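

Going from 3,5-dimethylphenyl to plain phenyl on this chain carbon gives a 3.8-fold lower number from compound 1 to compound 4 (0.57 log units; beyond the scatter) in this assay. So, for this pair, the two methyl groups are not needed for a low number at this position, and removing them lowers the number beyond the scatter. No available evidence explains this shift.

From the compounds shown here alone, it remains open whether a single methyl group, a chlorine atom or a pyridine ring in place of the phenyl would move the number further. Going by these compounds, it is also open whether the same change would have a similar effect on a different core.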